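Halogen swap on a shared core in a gastric cancer cell assay

This account rests on a few compounds, and the source may have more. Where it says the series, first, only, none or still open, it means among the compounds named here.

In a functional assay on BGC-823 cells (Homo sapiens) for antiproliferative activity, read by MTT assay, with a stated time of 48 h (on this read-out lower numbers stand for stronger inhibition and higher numbers for weaker inhibition), compound 1 `Clc1ccc(CSc2nnc(-c3cnccn3)o2)cc1` gives 30000 nM and compound 2 `Brc1ccc(CSc2nnc(-c3cnccn3)o2)cc1` gives 25700 nM. The change between them, (bromo in place of chloro on an aromatic carbon), produced a 1.2-fold lower number from compound 1 to compound 2 (0.07 log units; within the scatter). Compound 3 `Clc1ccc(CSc2nnc(-c3cnccn3)s2)cc1` has a core that differs from that of compound 1 in a way not broken down here. In this assay compound 3 gives 13400 nM. Compound 4 `Brc1ccc(CSc2nnc(-c3cnccn3)s2)cc1` is the not yet measured partner of compound 3, and the change from compound 3 to compound 4 is bromo in place of chloro on an aromatic carbon, the same change as from compound 1 to compound 2. The step from compound 3 to compound 4 is expected to be a 1.2-fold lower number from compound 3 to compound 4 (0.07 log units; within the scatter), resting on the measured 1.2-fold lower number from compound 1 to compound 2 (0.07 log units; within the scatter). Compound 4 is therefore estimated at 11500 nM in this assay, within 5500 nM and 24000 nM.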

Compound 4, half-maximal inhibitory concentration: 25200 nM
Estimate against measurement, compound 4: 2.2-fold (0.34 log units) below, and the stated range ends below it.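

In this assay bromo in place of chloro gives a 1.9-fold higher number from compound 3 to compound 4 (0.27 log units; within the scatter) on the second core shown, a step that lies within the scatter. Set beside the earlier step, it does not differ from it: the same change on two cores in this assay, a 1.2-fold lower number (0.07 log units; within the scatter) from compound 1 to compound 2 and a 1.9-fold higher number (0.27 log units; within the scatter) from compound 3 to compound 4, 2.2-fold (0.34 log units) apart, within the scatter of two such steps. This shows that, on these two cores, the change has no effect that can be told from the scatter, but two pairs do not prove that the steps are equal or that the same would hold on any further core.

The compounds shown leave open what fluoro, iodo, an amine or a carboxylic acid would give in place of the chloro. They also leave open how this change behaves on cores other than these two.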